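The compounds below may be only part of what the source reports. "The series", "measured", "known", "first", "only" and "open" are said of these compounds alone.

Compound 2 `COc1ccc(C(=O)/C=C/c2cc(-c3cc(OC)c(OC)c(OC)c3)n[nH]2)cc1OC` gives the larger of the two numbers recorded in a functional assay on HOP-62 cells (Homo sapiens) for cytotoxicity, read by sulforhodamine B assay, with a stated time of 48 h, tested at 0.01 uM (on this read-out lower numbers stand for a stronger effect and higher numbers for a weaker effect at the one concentration tested), where compound 2 gives 101%. The other measured compound, compound 1 `COc1cc(-c2cc(/C=C/C(=O)c3ccc(Cl)c(Cl)c3)[nH]n2)cc(OC)c1OC`, in this assay gives 99%, and the step of a number 2 percentage points higher from compound 1 to compound 2 (within the scatter) means the two compounds cannot be told apart on this read-out. Compound 3 `COc1cc(-c2cc(/C=C/C(=O)c3ccc(F)c(F)c3)[nH]n2)cc(OC)c1OC` has not yet been measured. It differs from compound 2 as follows: 3,4-difluorophenyl in place of 3,4-dimethoxyphenyl on a carbonyl carbon. Among the measured compounds shown here, the one measured step that bears on this change also exchanged one substituted phenyl group on the carbonyl carbon for another and was a number 2 percentage points higher from compound 1 to compound 2 (within the scatter). On that basis no step beyond the scatter is expected in this assay for compound 3, in either direction, and the expected step of a number 1 percentage points lower from compound 2 to compound 3 (within the scatter) is accordingly small. Compound 3 is estimated at 100%, with a range from 90% to 110%.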

Compound 3, a percentage reported as activity, at one concentration (the size of the read-out at that concentration, not a potency): 100%
For compound 3 middle estimate and measured number coincide at the digits printed; measured number inside the range.
By their numbers in this assay, from the lowest: compounds 1, 3 and 2 (each within the scatter of the next).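

With a third group on the carbonyl carbon, this position has now carried 3,4-dichlorophenyl, 3,4-dimethoxyphenyl and 3,4-difluorophenyl, and this assay separates none of them, with a number 1 percentage points lower from compound 2 to compound 3 (within the scatter) and a number 1 percentage points higher from compound 1 to compound 3 (within the scatter). The new group differs from 3,4-dimethoxyphenyl in its count of hydrogen-bond acceptors, 0 against 2, and the read-out still does not distinguish the two compounds. No measurement at hand offers an explanation for this flat result.

The compounds shown leave open whether an aminophenyl group, a carboxyphenyl group or a plain alkyl chain on the carbonyl carbon would move the number in this assay. They also leave open whether these three groups would separate at any concentration other than the single one tested.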